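The source may hold more compounds than are shown below. What is called first, only, known or untested is meant among the compounds shown, and "the series" means these compounds.

Measured so far in an in vitro assay on HEK385-7 cells for displacement of a labelled ligand from prostaglandin D2 receptor 2 (Homo sapiens); on this read-out higher numbers stand for weaker inhibition and lower numbers for stronger inhibition: compound 1 `O=C(O)Cc1sc(CS(=O)(=O)c2ccc(Cl)cc2)nc1-c1ccc(Cl)cc1` gives 1500 nM; compound 2 `O=C(O)Cc1sc(C(c2ccccc2)c2ccc(F)cc2)nc1-c1ccc(Cl)cc1` gives 17 nM; compound 3 `N#Cc1cc(-c2nc(C(c3ccc(F)cc3)c3ccc(F)cc3)sc2CC(=O)O)ccc1F` gives 57 nM.

Among these three numbers compound 3 stands second highest: compound 2 gives a lower number and compound 1 a higher one, each gap lying beyond the scatter. Compound 4 `COc1cc(-c2nc(C(c3ccc(F)cc3)c3ccc(F)cc3)sc2CC(=O)O)ccn1` differs from compound 3 in one place, (2-methoxypyridin-4-yl in place of 3-cyano-4-fluorophenyl on an aromatic carbon). Going by the values given here, no measured pair shows this change, so its effect is unknown. Compound 2 and compound 3 show that aryl groups of this kind both give low numbers in this assay, so compound 4 is expected to stay close to compound 3, with a step of a 1.1-fold higher number from compound 3 to compound 4 (0.02 log units; within the scatter) not clearly beyond the scatter. Compound 4 is estimated at 60 nM, within 20 nM to 180 nM.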

Compound 4, half-maximal inhibitory concentration: 29 nM
For compound 4 the middle estimate is 2.1-fold (0.32 log units) above the measured one, within the range that was stated.
By their numbers in this assay, from the lowest: compounds 2, 4 and 3 (each within the scatter of the next, the first and the last beyond it); then compound 1.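

In this assay, placing 2-methoxypyridin-4-yl instead of 3-cyano-4-fluorophenyl on the aromatic carbon next to the ring nitrogen gives a 2.0-fold lower number from compound 3 to compound 4 (0.29 log units; within the scatter). This position therefore tolerates a six-membered aromatic ring with a hetero atom as well as one of carbon only, with neither the nitrile nor the fluorine of the leaving group required for a low number. Nothing shown here explains the step.

The compounds shown leave open what the methoxy group and the ring nitrogen each contribute. They also leave open whether a non-aromatic group, such as morpholine, would be tolerated here.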